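The source may hold more compounds than are shown below. What is called first, only, known or untested is meant among the compounds shown, and "the series" means these compounds.

Working notes on the series. In an ADME assay on HepG2 2.2.15 cells (Homo sapiens) for cytotoxicity (on this read-out higher numbers stand for lower toxicity in this test and lower numbers for higher toxicity in this test), the three measured compounds span a modest range. Compound 1 `O=c1[nH]c2ccc(Cl)cc2c(-c2ccccc2Cl)c1CCO` gives 380000 nM, compound 2 `O=CCc1c(-c2ccccc2Cl)c2cc(Cl)ccc2[nH]c1=O` gives 120000 nM, and compound 3 `O=C(OCCc1c(-c2ccccc2Cl)c2cc(Cl)ccc2[nH]c1=O)C1CCCCC1` gives 38000 nM. Compound 3 therefore stands lowest of the three numbers: the step of a 10-fold lower number from compound 1 to compound 3 (1.00 log units; beyond the scatter) is the largest seen so far, while a 3.2-fold lower number from compound 2 to compound 3 (0.50 log units; beyond the scatter) and a 3.2-fold lower number from compound 1 to compound 2 (0.50 log units; beyond the scatter) are smaller.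

Compound 4 `COc1cccc(/C=C/C(=O)OCCc2c(-c3ccccc3Cl)c3cc(Cl)ccc3[nH]c2=O)c1` keeps the ester of compound 3 and alters only the acyl part: 2-(3-methoxyphenyl)ethenyl in place of cyclohexyl on a carbonyl carbon. Going by the values given here, no measured step varies the acyl group while holding the ester in place, so the only bearing steps are those that build the ester from the free alcohol or aldehyde, and the step from compound 1 to compound 3 shows that an acyl group on that oxygen lowers the number in this assay. Whether the 2-(3-methoxyphenyl)ethenyl group pushes further in that direction is not resolved by the data; the expectation is for a step of a 1.5-fold lower number from compound 3 to compound 4 (0.18 log units; within the scatter), that is, a small lowering within or near the usual scatter. Compound 4 is thus estimated at 25000 nM, with a range from 8000 nM to 80000 nM.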

Compound 4, half-maximal cytotoxic concentration: > 1300000 nM
Compound 4: only a limit was reported; the forecaster's own chance of this, stated with the estimate: 5%; middle value at least 52-fold (1.71 log units) away from the limit.
By their numbers in this assay, from the lowest: compound 3; then compound 2; then compound 1. At a limit, above all of these: compound 4.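

Going by these compounds alone, on the carbonyl carbon of the ester, 2-(3-methoxyphenyl)ethenyl in place of cyclohexyl gives an at least 34-fold higher number from compound 3 to compound 4 (1.53 log units; beyond the scatter) in this assay, so the acyl part alone can move this read-out widely, which no earlier step could show. The earlier steps suggested that acylating the oxygen lowers the number, as in a 10-fold lower number from compound 1 to compound 3 (1.00 log units; beyond the scatter), but that now holds only for cyclohexylcarbonyl and not for the ester as such, since compound 4 sits above all the other compounds shown. Compound 4 is recorded only as a limit, so the size of its step has a floor and no fixed value: the limit of > 1300000 nM in this assay, at which 1 of the 4 values shown sits.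

The compounds shown do not separate the contributions of the double bond, the aromatic ring and the methoxy group within the entering group, so which of these parts goes with the higher number stays open. Also open, on these data alone, is how the series behaves with other acyl groups on this oxygen, such as a plain phenyl, a saturated 3-(3-methoxyphenyl)propanoyl chain, or an acyl group carrying an amine or a carboxylic acid.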